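Removing one chlorine from a dichlorinated benzyl ether

The source may report more compounds than this note shows. Statements on the series, on what has been measured and on what is new or still open speak of the compounds shown alone.

Three compounds of a shared core carry a benzyl ether on it. Compound 1 `Cc1ccc(COc2ccc3c(c2)C(C)(C)C(=O)N3)cc1` differs in its core and was reported as "not active" (no number reported) in an assay on cells for inhibition of Amine oxidase [flavin-containing] B (Homo sapiens), read by fluorescence, with stated times of 30 min and 15 min, tested at 1 uM; on this read-out lower numbers stand for less inhibition and higher numbers for more inhibition at the one concentration tested (going by the name of the read-out). Compound 2 `Cn1c(=O)[nH]c2ccc(OCc3ccc(Cl)cc3)cc21` gives 8.29% in this assay. Compound 3 `Cn1c(=O)[nH]c2ccc(OCc3ccc(Cl)c(Cl)c3)cc21` gives 32.4% in this assay, which is the highest of the two numbers; compound 1 has no number to compare. Within the data shown here, the only step measured so far, a number 24.1 percentage points higher from compound 2 to compound 3 (beyond the scatter), shows what adding a chloro group brought.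

Compound 4 `Cn1c(=O)[nH]c2ccc(OCc3cccc(Cl)c3)cc21` is next. Its change from compound 3 is hydrogen in place of chloro on an aromatic carbon, at a place on an aromatic carbon of a six-membered aromatic ring of carbon only, ortho to a chloro group and para to a large group. Among the measured compounds shown here, no measured step removes a chloro at this place; the one step that bears on it, a number 24.1 percentage points higher from compound 2 to compound 3 (beyond the scatter), runs the other way and added a chloro elsewhere on that ring. Since compound 2 with a single chloro gave 8.29%, compound 4 with a single chloro at a different place is expected to fall below compound 3, by about a number 17.4 percentage points lower from compound 3 to compound 4 (beyond the scatter). Compound 4 is therefore estimated at 15%, within 3% to 30%.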

Compound 4, a percentage reported as inhibition, at one concentration (the size of the read-out at that concentration, not a potency): 8.89%
The estimate for compound 4 lay 6.1 percentage points above the measured number; measured number inside the range.
By their numbers in this assay, from the lowest: compounds 2 and 4 (each within the scatter of the next); then compound 3.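

Removing the chloro that sits ortho to a chloro group and para to a large group costs as much in this assay as the earlier step gained at the other chloro: a number 23.5 percentage points lower from compound 3 to compound 4 (beyond the scatter), set against a number 24.1 percentage points higher from compound 2 to compound 3 (beyond the scatter) for the step that added a chloro to the ring. Compound 3 therefore loses a step beyond the scatter whichever of its two chloro groups is taken away, so this place matters on this ring when the second chloro is present, and neither one-place neighbour of compound 3 keeps its level of inhibition. No measurement shown explains why the second chloro matters at this place, so the step stands as an observation only.

The compounds shown leave open whether the gain depends on chlorine itself, or whether a fluoro, a methyl, a methoxy or an amine at this place would serve the same way. They also leave open whether the same pair of chloro groups would lift the core of compound 1, which carries a methyl on the benzyl ring instead.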